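Para-substituent survey on the triazole aryl ring

This account rests on a few compounds, and the source may have more. Where it says the series, first, only, none or still open, it means among the compounds named here.

Measured compounds:
compound 1, `CC1(C)[C@H]2CC[C@]1(C)N(Cc1cn(-c3ccc(Cl)cc3)nn1)C(=O)C2`, 160 nM
compound 2, `Cc1ccc(-n2cc(CN3C(=O)C[C@@H]4CC[C@@]3(C)C4(C)C)nn2)cc1`, 40 nM
compound 3, `CC1(C)[C@H]2CC[C@]1(C)N(Cc1cn(-c3ccccc3)nn1)C(=O)C2`, 50 nM

All three share one core and differ only on the aryl ring of the triazole. In a functional assay on OVCAR-3 cells (Homo sapiens) for inhibition, read by MTT assay, with a stated time of 24 h (a higher number here means a weaker inhibitor, a lower number a stronger inhibitor), compound 1 gives the highest number of the three; compound 2 and compound 3 sit close together, a 1.3-fold higher number from compound 2 to compound 3 (0.10 log units; within the scatter). Compound 3 stands second highest of the three numbers, separated from compound 1 by a 3.2-fold lower number from compound 1 to compound 3 (0.51 log units; beyond the scatter).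

Compound 4, `CC1(C)[C@H]2CC[C@]1(C)N(Cc1cn(-c3ccc(F)cc3)nn1)C(=O)C2`, is not yet measured. It differs from compound 3 by fluoro in place of hydrogen on an aromatic carbon. The relevant measured steps are a 3.2-fold lower number from compound 1 to compound 3 (0.51 log units; beyond the scatter) and a 4.0-fold lower number from compound 1 to compound 2 (0.60 log units; beyond the scatter): the larger chloro raised the number, while methyl left it where hydrogen does. Fluoro is a halogen like chloro but smaller, so a step somewhere between those two outcomes is expected: a small rise in this assay, likely within the scatter, a 1.4-fold higher number from compound 3 to compound 4 (0.15 log units; within the scatter). Compound 4 is therefore estimated at 70 nM, within 30 nM to 180 nM.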

Compound 4, half-maximal inhibitory concentration: 200 nM
Beside the measured number, compound 4's estimate is 2.9-fold (0.46 log units) below it; the measured number lies above the stated range.
By their numbers in this assay, from the lowest: compounds 2 and 3 (each within the scatter of the next); then compounds 1 and 4 (each within the scatter of the next).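

In this assay, a single fluoro on the aromatic carbon para to a large group is enough to move the number well away from the unsubstituted phenyl, with a 4.0-fold higher number from compound 3 to compound 4 (0.60 log units; beyond the scatter). Fluoro in place of methyl gives a 5.0-fold higher number from compound 2 to compound 4 (0.70 log units; beyond the scatter), while fluoro in place of chloro gives a 1.3-fold higher number from compound 1 to compound 4 (0.10 log units; within the scatter), so among these four compounds the two halogens read alike and stand apart from hydrogen and methyl, a split that chloro alone could not establish. No available evidence accounts for this split.

Going by these compounds, whether a bromo or a methoxy group at this place would read with the halogens or with methyl remains open. Also open, on these data alone, is whether fluoro on another carbon of the phenyl ring would give a step of similar size.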